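Polar pyrrolidine substituents on a chromone core: predicting compound 4

The source may report more compounds than this note shows. Statements on the series, on what has been measured and on what is new or still open speak of the compounds shown alone.

Compound 1 `Cc1cc(=O)c2c(O)c(CN3CCCC3)c(O)c([C@H]3CCN(C)C[C@H]3O)c2o1` gives 28% in a functional assay on MIA PaCa-2 cells (Homo sapiens) for inhibition, read by MTT assay, with a stated time of 48 h, tested at 10 uM; on this read-out lower numbers stand for less inhibition of growth and higher numbers for more inhibition of growth at the one concentration tested.
Compound 2 `Cc1cc(=O)c2c(O)c(CN3CCCC3CO)c(O)c([C@H]3CCN(C)C[C@H]3O)c2o1` gives 13% in this assay.
Compound 3 `CCOC(=O)N1CCN(Cc2c(O)c([C@H]3CCN(C)C[C@H]3O)c3oc(C)cc(=O)c3c2O)CC1` gives 4% in this assay.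

Compound 3 stands lowest of the three, a result beyond the scatter only against compound 1 a number 24 percentage points lower from compound 1 to compound 3 (beyond the scatter) and within it against compound 2 a number 9 percentage points lower from compound 2 to compound 3 (within the scatter). Compound 4 `Cc1cc(=O)c2c(O)c(CN3CC(O)CC3C(=O)O)c(O)c([C@H]3CCN(C)C[C@H]3O)c2o1` differs from compound 3 in one place: 2-carboxy-4-hydroxypyrrolidin-1-yl in place of 4-(ethoxycarbonyl)piperazin-1-yl on a saturated chain carbon bound to an aromatic carbon. Among the measured compounds shown here, no measured step covers this exact exchange. The step of a number 15 percentage points lower from compound 1 to compound 2 (beyond the scatter) shows that adding a hydroxymethyl to the pyrrolidine ring lowered growth inhibition, and compound 2 and compound 3 sit close together. A pyrrolidine carrying both a carboxy and a hydroxy group is therefore expected to land near compound 3, with a number 4 percentage points higher from compound 3 to compound 4 (within the scatter) lying within the scatter. Compound 4 is estimated at 8%, ranging from 0% to 22%.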

Compound 4, percent growth inhibition at one concentration: 23%
Estimate against measurement, compound 4: 15 percentage points below; measured number outside the range, above it.
By their numbers in this assay, from the lowest: compounds 3, 2, 4 and 1 (each within the scatter of the next, the first and the last beyond it).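

At this position, on a saturated chain carbon bound to an aromatic carbon, putting 2-carboxy-4-hydroxypyrrolidin-1-yl in place of 4-(ethoxycarbonyl)piperazin-1-yl gives a number 19 percentage points higher from compound 3 to compound 4 (beyond the scatter) in this assay. Against the other two pyrrolidines, the readings are a number 10 percentage points higher from compound 2 to compound 4 (within the scatter) and a number 5 percentage points lower from compound 1 to compound 4 (within the scatter), so substituents on this ring do not always bring a reading close to compound 3 alone. No measurement here accounts for this result.

As far as these compounds go, it remains open whether the carboxylic acid or the hydroxy group matters more. From the compounds shown here alone, a pyrrolidine carrying an amine on the ring also remains untested in this comparison.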